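Phenoxy for methyl on the benzylamine arm

This account rests on a few compounds, and the source may have more. Where it says the series, first, only, none or still open, it means among the compounds named here.

This account follows a series of phenylpropanoic acids in which a benzyl amine arm is varied. Compound 1 `O=C(O)CCc1ccc(NCc2ccc3ccccc3c2)cc1` gives 123% in a functional assay on CHO cells for agonist activity at Free fatty acid receptor 1 (Homo sapiens), read by reporter gene assay; on this read-out higher numbers stand for larger maximal responses and lower numbers for smaller maximal responses. Compound 2 `Cc1ccc(CNc2ccc(CCC(=O)O)cc2)cc1` gives 152% in this assay, and compound 3 `O=C(O)CCc1ccc(NCc2cc(C(F)(F)F)cnc2Cl)cc1` gives 112%. Compound 2 therefore stands highest of the three: the value of compound 1 lies below it by a gap beyond the scatter, and the value of compound 3 lies still further below, also beyond the scatter.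

Compound 4 `O=C(O)CCc1ccc(NCc2ccc(Oc3ccccc3)cc2)cc1` has not been measured in this assay. It differs from compound 2 at one place: phenoxy in place of methyl on an aromatic carbon. Within the data shown here, no measured pair in the set shows this change, so its size can only be estimated from the three numbers above. Since compound 1 gives 123% and compound 3 gives 112%, both below compound 2, a downward step beyond the scatter is expected from compound 2 to compound 4, of size a number 27 percentage points lower from compound 2 to compound 4 (beyond the scatter). Compound 4 is accordingly expected to reach about 125%, with a range from 95% to 160%.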

Compound 4, largest response reached (reported as percent of maximum), in percent of the reference or control that the assay uses: 139%
Estimate against measurement, compound 4: 14 percentage points below, and the stated range covers the measured number.
By their numbers in this assay, from the lowest: compound 3; then compound 1; then compound 4; then compound 2.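

In this assay, among these compounds, the exchange of methyl for phenoxy gives the first direct reading at this position, and the step is a number 13 percentage points lower from compound 2 to compound 4 (beyond the scatter) in a modest drop. The aromatic carbon para to a large group thus takes seven heavy atoms, including a further six-membered aromatic ring, in place of one, and compound 4 still reaches 139% on this read-out. No supporting data bear on what lies behind this step.

The compounds shown leave open whether the added ring or the linking oxygen accounts for the step, a question that a phenyl group on the same carbon would address. They also leave open how a methoxy group, a benzyloxy group or an amine would compare at this position.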